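Taking the chloro off compound 1

The compounds below may be only part of what the source reports. "The series", "measured", "known", "first", "only" and "open" are said of these compounds alone.

In a functional assay on QGY cells (Homo sapiens) for cytotoxicity, read by MTT assay, with a stated time of 48 h (on this read-out lower numbers stand for stronger inhibition and higher numbers for weaker inhibition), compound 1 `COc1cc([C@@H]2C[C@]2(CO)C(=O)Nc2ccccc2Cl)cc(OC)c1OC` gives 15700 nM, the lowest number here. Compound 2 `COc1cc([C@H]2C[C@]2(CO)C(=O)Nc2ccccc2Cl)cc(OC)c1OC`, which differs at one stereocentre, gives 40700 nM. The mirror image of compound 1 is compound 3 `COc1cc([C@H]2C[C@@]2(CO)C(=O)Nc2ccccc2Cl)cc(OC)c1OC`, which reads > 100000 nM, a limit of the assay. Compound 4 `COc1cc([C@@H]2C[C@]2(CO)C(=O)Nc2ccccc2)cc(OC)c1OC` keeps the configuration of compound 1 but carries hydrogen in place of chloro on an aromatic carbon. For the measured compounds named here, no measured step touches this group. Going by the values given here, the only guides are changes of configuration, a 2.6-fold higher number from compound 1 to compound 2 (0.41 log units; beyond the scatter) and an at least 6.3-fold higher number from compound 1 to compound 3 (0.80 log units; beyond the scatter). Going by the size of a 2.6-fold higher number from compound 1 to compound 2 (0.41 log units; beyond the scatter), a modest step towards a higher number is expected, a 2.2-fold higher number from compound 1 to compound 4 (0.35 log units; beyond the scatter). Compound 4 is estimated at 35000 nM, with an expected range of 11000 nM to 100000 nM.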

Compound 4, half-maximal inhibitory concentration: 51300 nM
Compound 4: middle estimate off by 1.5-fold (0.17 log units), on the low side; the range from low to high includes it.
By their numbers in this assay, from the lowest: compound 1; then compounds 2 and 4 (each within the scatter of the next). At a limit, above all of these: compound 3.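

In this assay, hydrogen in place of chloro on an aromatic carbon, ortho to a large group, gives a 3.3-fold higher number from compound 1 to compound 4 (0.51 log units; beyond the scatter). The earlier compounds shown here varied only configuration, whereas this step shows that the group at this ring position also matters: with the configuration of compound 1 kept, inhibition is weaker without the chloro. Nothing given here explains why this happens.

From the compounds shown here alone, whether bromo, methyl or methoxy at this position would read lower than chloro stays open. So does whether removing the chloro has a similar effect in the other configurations.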